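The compounds below may be only part of what the source reports. "The series", "measured", "known", "first", "only" and "open" are said of these compounds alone.

Measured so far in a functional assay on A549 cells (Homo sapiens) for cytotoxicity, read by MTT assay; on this read-out lower numbers stand for stronger inhibition and higher numbers for weaker inhibition:
- compound 1 `N#Cc1c(Nc2ccccc2)c(Cl)c2nc(N)nc(N)c2c1F`: > 1000 ug/mL
- compound 2 `N#Cc1c(Nc2ccccc2)c(F)c2nc(N)nc(N)c2c1F`: > 1000 ug/mL

Each of these entries is a limit of the assay and not a number. Compound 2 stands at > 1000 ug/mL, which is a limit. Going by the values given here, the same holds for the whole series so far: the limit of > 1000 ug/mL in this assay, at which 2 of the 2 values shown sit.

The next compound is compound 3 `CCN(CC)c1c(C#N)c(F)c2c(N)nc(N)nc2c1F`, with diethylamino in place of anilino on an aromatic carbon, ortho to a cyano group: diethylamino in place of anilino on an aromatic carbon.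

Among the compounds with values here, only one measured step exists, a step that the two limits leave unreadable from compound 1 to compound 2, with fluoro in place of chloro on an aromatic carbon. Within the data shown here, it is a change at a different place and gives no size to carry over, and no measured step covers the exchange of anilino. No direction can therefore be drawn from the data, and no step beyond the scatter is expected in this assay. The expectation rests on compound 2 at > 1000 ug/mL, so a further limit is the likeliest report. The expected step is a number no higher from compound 2 to compound 3 (the limit leaves the size open). Compound 3 is estimated at 1000 ug/mL, with an expected range from 400 ug/mL to 2500 ug/mL.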

Compound 3, half-maximal inhibitory concentration: 26.5 ug/mL
The estimate for compound 3 lay 38-fold (1.58 log units) above the measured number; measured number below the stated range.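

In this assay, diethylamino in place of anilino, on the aromatic carbon ortho to a cyano group, gives an at least 37-fold lower number from compound 2 to compound 3 (1.57 log units; beyond the scatter). Going by these compounds alone, this is the first readable step, and it shows that the group at this position can move the read-out away from the limit and to a real number; the exchange removes a six-membered aromatic ring of carbon only and a hydrogen-bond donor and brings in a group with no ring. The one earlier step, fluoro in place of chloro, cannot be read, and the limit remains the most frequent entry in the series: the limit of > 1000 ug/mL in this assay, at which 2 of the 3 values shown sit.

The single exchange changes the ring and the hydrogen-bond donor together, so the compounds shown do not tell which of these goes with the step, and a cyclohexylamino group, an N-methylanilino group or a dimethylamino group at the same carbon would begin to separate them. Within the data shown here, it also stays open whether chloro in place of the fluoro group para to a fused ring would matter once diethylamino is present, since the only comparison of those two halogens sits at the limit.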